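A few compounds are considered here, and "the series" means these few. Any claim that something is new, unique, unknown or untested is made for them only; others in the source may bear on it.

Among the three compounds measured so far, compound 3 `C=C(CC)C(=O)c1ccc(OCC(=O)Nc2ccc(C#N)cc2)c(Cl)c1Cl` stands at the top of the numbers: in a functional assay on CLL cells (Homo sapiens) for cytotoxicity, read by MTT assay, with a stated time of 48 h (on this read-out lower numbers stand for an effect already at smaller amounts and higher numbers for an effect only at larger amounts of compound), compound 3 gives 7800 nM. Its nearest neighbour is compound 1 `C=C(CC)C(=O)c1ccc(OCC(=O)Nc2ccc(O)cc2)c(Cl)c1Cl`, which in this assay gives 6400 nM, the step being a 1.2-fold higher number from compound 1 to compound 3 (0.09 log units; within the scatter). Furthest away is compound 2 `C=C(CC)C(=O)c1ccc(OCC(=O)NCO[N+](=O)[O-])c(Cl)c1Cl`, which in this assay gives 4100 nM; that step is a 1.9-fold higher number from compound 2 to compound 3 (0.28 log units; within the scatter), and between the other two compounds it is a 1.6-fold lower number from compound 1 to compound 2 (0.19 log units; within the scatter). None of the three steps reaches beyond the scatter.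

Compound 4 `C=C(CC)C(=O)c1ccc(OCC(=O)NCCCN2CCCC2=O)c(Cl)c1Cl` is the next structure to be tested. It differs from compound 3 at the amide-type nitrogen: 3-(2-oxopyrrolidin-1-yl)propyl in place of 4-cyanophenyl on an amide-type nitrogen. The two steps that already touch this position, a 1.6-fold lower number from compound 1 to compound 2 (0.19 log units; within the scatter) and a 1.9-fold higher number from compound 2 to compound 3 (0.28 log units; within the scatter), both exchanged the whole group on that nitrogen, once an aromatic ring for an acyclic chain and once back, and in neither case did the number move beyond the scatter. On that basis the step of a 1.3-fold lower number from compound 3 to compound 4 (0.11 log units; within the scatter) is expected to stay within the scatter, with no clear direction. Compound 4 is therefore estimated at 6000 nM in this assay, within a range from 2500 nM to 14000 nM.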

Compound 4, half-maximal effective concentration: 13800 nM
Beside the measured number, compound 4's estimate is 2.3-fold (0.36 log units) below it; measured number inside the range.
By their numbers in this assay, from the lowest: compounds 2, 1, 3 and 4 (each within the scatter of the next, the first and the last beyond it).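

In this assay, among these compounds, the group on the amide-type nitrogen now produces steps beyond the scatter for the first time, though both are modest (a 3.4-fold higher number from compound 2 to compound 4 (0.53 log units; beyond the scatter); a 2.2-fold higher number from compound 1 to compound 4 (0.33 log units; beyond the scatter)). The exchange of 4-cyanophenyl for 3-(2-oxopyrrolidin-1-yl)propyl itself stays within the scatter (a 1.8-fold higher number from compound 3 to compound 4 (0.25 log units; within the scatter)), so this position is less indifferent than the first three compounds suggested, yet compound 3 cannot be separated from compound 4 here. An aromatic ring against a chain does not sort the series either, since compound 2 and compound 4 both carry a saturated chain on this nitrogen and still stand at the two ends of the numbers, with the aryl compounds 1 and 3 in the range between them. Nothing available here explains why the number shifts with this group.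

As far as these compounds go, it remains open whether the shift follows the 2-oxopyrrolidine ring or the propyl chain that carries it, since the two enter together in compound 4. From the compounds shown here alone, how a simple amine, a carboxylic acid or a longer chain on this nitrogen would stand against these four compounds also remains open.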